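The source may hold more compounds than are shown below. What is called first, only, known or untested is meant among the compounds shown, and "the series" means these compounds.

Compound 1 `COc1ccc(-c2cc3ccc(OC)cc3nc2Nc2ccc(NC(=O)CN3CCCC3)cc2)cc1` and compound 3 `COc1ccc(-c2cc3cc(OC)ccc3nc2Nc2ccc(NC(=O)CN3CCCC3)cc2)cc1` share the same atoms joined differently; the difference between their two cores is not broken down here. In a functional assay on MCF7 cells (Homo sapiens) for antiproliferative activity, read by MTT assay, with a stated time of 48 h (a higher number here means a weaker inhibitor, a lower number a stronger inhibitor), compound 1 gives 6600 nM, and compound 3 gives 7290 nM, a pair that cannot be told apart. Compound 2 `COc1ccc(-c2cc3ccc(OC)cc3nc2Nc2ccc(NC(=O)CN3CCCCC3)cc2)cc1` carries the change (piperidin-1-yl in place of pyrrolidin-1-yl on a saturated chain carbon bound to a carbonyl carbon), and in this assay compound 2 gives 47900 nM, so that a 7.3-fold higher number from compound 1 to compound 2 (0.86 log units; beyond the scatter). Compound 4 `COc1ccc(-c2cc3cc(OC)ccc3nc2Nc2ccc(NC(=O)CN3CCCCC3)cc2)cc1` is the same kind of change made on the core of compound 3, (piperidin-1-yl in place of pyrrolidin-1-yl on a saturated chain carbon bound to a carbonyl carbon), and it has not yet been measured. Because compound 1 to compound 2 shows a 7.3-fold higher number from compound 1 to compound 2 (0.86 log units; beyond the scatter), a step of about the same size is expected from compound 3 to compound 4, a 6.2-fold higher number from compound 3 to compound 4 (0.79 log units; beyond the scatter). Compound 4 is therefore estimated to give 45000 nM, most likely between 15000 nM and 130000 nM.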

Compound 4, half-maximal inhibitory concentration: > 50000 nM
Compound 4: a limit, no number; the forecaster's own chance of this, stated with the estimate: 5%; middle value at least 1.1-fold (0.04 log units) away from the limit.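

In this assay, the same swap of pyrrolidin-1-yl for piperidin-1-yl on the core of compound 3 gives an at least 6.8-fold higher number from compound 3 to compound 4 (0.83 log units; beyond the scatter), so the change raises the number, meaning a weaker inhibitor, on both cores: the same change on two cores in this assay, a 7.3-fold higher number (0.86 log units; beyond the scatter) from compound 1 to compound 2 and an at least 6.8-fold higher number (0.83 log units; beyond the scatter) from compound 3 to compound 4; the limit leaves it open whether they differ. Compound 4 gives > 50000 nM, which is a limit of the assay and not a number. On these data alone, the direction of the change therefore carries over between these two cores, but whether the two steps match in size stays unknown, and two cores cannot speak for the whole series.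

The compounds shown leave open what morpholin-4-yl or a dimethylamino group would give in place of pyrrolidin-1-yl. They also leave open what a longer chain carrying pyrrolidin-1-yl would give on either core.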